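The compounds below may be only part of what the source reports. "The series", "measured", "known", "first", "only" and "open" are said of these compounds alone.

Three compounds were measured in a functional assay on the whole organism (artery, strain albino) with Rattus norvegicus as the target, with a stated time of 300 min, at a dose of 10 mg/kg by the oral route; on this read-out higher numbers stand for more inhibition at the one dose given (going by the name of the read-out) and lower numbers for less inhibition:

compound 1, `COc1ccc(C2N=C(SCc3ccccc3)NC(C)=C2C(=O)Nc2ccc(F)cc2)cc1OC`: 7.2%
compound 2, `COc1ccc(C2N=C(SCc3ccc(Cl)cc3)NC(C)=C2C(=O)Nc2ccc(F)cc2)cc1OC`: 31.3%
compound 3, `CC1=C(C(=O)Nc2ccc([N+](=O)[O-])cc2)C(c2ccc(Br)cc2)N=C(SCc2ccccc2)N1`: 29.7%

From compound 1 to compound 2 the change is chloro in place of hydrogen on an aromatic carbon, the place being para to a large group, and the step in this assay is a number 24.1 percentage points higher from compound 1 to compound 2 (beyond the scatter). Compound 3 sits on a different core; how that core differs from the core of compound 1 is not broken down here. Compound 3 and compound 2 give values within the scatter of each other, while compound 1 lies beyond the scatter below both.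

Compound 4, `CC1=C(C(=O)Nc2ccc([N+](=O)[O-])cc2)C(c2ccc(Br)cc2)N=C(SCc2ccccc2Cl)N1`, is not yet measured. It differs from compound 3 by chloro in place of hydrogen on an aromatic carbon, the place being ortho to a large group. This is the same kind of change as that from compound 1 to compound 2, though not the same, since the place on the ring differs and the core is another. Resting on the earlier step, compound 4 is expected to gain over compound 3 by about a number 10.3 percentage points higher from compound 3 to compound 4 (beyond the scatter), the gain being taken smaller than the earlier one because of a number 24.1 percentage points higher from compound 1 to compound 2 (beyond the scatter) arising at a different place and core. The estimate for compound 4 is 40%, between 22% and 58%.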

Compound 4, a percentage reported as inhibition, in the whole organism at one dose (the size of the read-out at that dose, not a potency): 16.9%
The estimate for compound 4 lay 23.1 percentage points above the measured number; measured number outside the range, below it.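

In this assay the chloro change gives a number 12.8 percentage points lower from compound 3 to compound 4 (beyond the scatter), so on this evidence the change does not carry from one core to another as a fixed gain, and its direction is not kept either: the same change on two cores in this assay, a number 24.1 percentage points higher (beyond the scatter) from compound 1 to compound 2 and a number 12.8 percentage points lower (beyond the scatter) from compound 3 to compound 4, 36.9 percentage points apart, beyond the scatter of two such steps. The two steps differ in more than the core, since the chloro in compound 4 stands ortho to a large group, as in 2-chlorobenzyl, while the chloro in compound 2 stands at another place on the ring. The pair therefore does not show whether the core, the place on the ring or both together set the sign of the step, and two steps give no rule for the series.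

The compounds shown leave open what chloro does at the same place on both cores, which would separate the core from the place. They also leave open how the benzyl ring of compound 3 responds to a group other than chloro at that place, such as an amine or a carboxylic acid.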